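The source may hold more compounds than are shown below. What is called first, only, known or untested is meant among the compounds shown, and "the series" means these compounds.

Measured compounds:
Compound 1 `Cc1nn(C2COC2)cc1Nc1nc(N)c2c(C#N)c(N3CCC[C@H]3C)n(C)c2n1` gives 240 nM in an assay on HEK293 cells for inhibition of Leucine-rich repeat serine/threonine-protein kinase 2 (Homo sapiens), with a stated time of 48 h; on this read-out lower numbers stand for stronger inhibition and higher numbers for weaker inhibition.
Compound 2 `Cc1nn(C2CCOC2)cc1Nc1nc(N)c2c(C#N)c(N3CCC[C@H]3C)n(C)c2n1` gives 140 nM; 260 nM (2 entries) in this assay.
Compound 3 `Cc1nn(C)cc1Nc1nc(N)c2c(C#N)c(N3CCC[C@H]3C)n(C)c2n1` gives 190 nM in this assay.

Of the two compounds with a single number, compound 3 holds the lower one, but its nearest neighbour, compound 1, sits within the scatter of it, so no order between them can be read. The repeated entries of compound 2 the several entries of compound 2 in this assay, 140 nM; 260 nM (2 entries) show how far single numbers of one compound can drift in this assay.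

Compound 4 `Cc1nn(CC2(O)COC2)cc1Nc1nc(N)c2c(C#N)c(N3CCC[C@H]3C)n(C)c2n1` differs from compound 3 in one place: 3-hydroxyoxetan-3-yl in place of hydrogen on a saturated chain carbon bound to an aromatic nitrogen. Among the measured compounds shown here, the only measured step that bears on the group carried by this aromatic nitrogen is a 1.3-fold lower number from compound 1 to compound 3 (0.10 log units; within the scatter), where swapping a methyl for a four-membered oxygen ring left the number essentially where it was. Compound 2, with an oxolane on the same nitrogen, likewise sits near the other two. The new group adds a hydroxyl to a ring of the same size, one bond further out. No change beyond the scatter is therefore expected for the step of a 1.1-fold higher number from compound 3 to compound 4 (0.02 log units; within the scatter). Compound 4 is estimated at 200 nM, with a range from 90 nM to 450 nM.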

Compound 4, half-maximal inhibitory concentration: 410 nM
Beside the measured number, compound 4's estimate is 2.1-fold (0.31 log units) below it; the measured number falls inside the stated range.
By their numbers in this assay, from the lowest: compounds 3, 1 and 4 (each within the scatter of the next, the first and the last beyond it).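

With (3-hydroxyoxetan-3-yl)methyl on the aromatic nitrogen, the series shows its first single-change step past the scatter at this position: a 2.2-fold higher number from compound 3 to compound 4 (0.33 log units; beyond the scatter) shows that the position is not wholly indifferent to the group it carries. The same group set against the oxetan-3-yl of compound 1 gives a 1.7-fold higher number from compound 1 to compound 4 (0.23 log units; within the scatter) and so yields no order between those two compounds. The step from methyl is modest, and a single compound can spread by a similar margin in this assay, so it supports only a cautious reading: the several entries of compound 2 in this assay, 140 nM; 260 nM (2 entries).

On these data alone, it remains open whether the step goes with the hydroxyl, with the four-membered ring or with both. The compounds shown also leave open how a plain ethyl chain, a 2-hydroxyethyl chain or a chain ending in an amine would read at this place.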